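The compounds below may be only part of what the source reports. "The series", "measured", "known", "first", "only" and "open" are said of these compounds alone.

Of the compounds shown here, three built on the same core have been tested in a functional assay on the whole organism (strain L.) for inhibition, with Echinochloa crus-galli as the target, with a stated time of 72 h, tested at 100 mg/L; a higher number here means more inhibition of growth at the concentration tested, a lower number less inhibition of growth. Compound 1, `COc1cc(Cl)nc(NC(=S)NC(=O)c2c(-c3ccc(Cl)cc3Cl)noc2C)n1`, gives 56.3%, the lowest of the three. Compound 2, `COc1cc(OC)n2s/c(=N\C(=O)c3c(-c4ccc(Cl)cc4Cl)noc3C)nc2n1`, gives 85.6%, and compound 3, `CSc1cc(C)nc2n/c(=N/C(=O)c3c(-c4ccc(Cl)cc4Cl)noc3C)sn12`, gives 75.4%; both numbers stand beyond the usual scatter above that of compound 1. Among the compounds with values here, the three differ in more than one place, so no single structural step between them can be read off.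

Compound 4, `COc1cc(OC)nc(NC(=S)NC(=O)c2c(-c3ccc(Cl)cc3Cl)noc2C)n1`, has not yet been measured. Next to compound 1 it shows one change: methoxy in place of chloro on an aromatic carbon. Within the data shown here, no comparable step among the measured compounds exists to guide the size. The step from compound 1 to compound 4 is expected to be small, a number 5.7 percentage points higher from compound 1 to compound 4 (within the scatter), barely beyond the scatter if at all. Compound 4 is therefore estimated at 62%, within 42% to 80%.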

Compound 4, percent growth inhibition at one concentration: 60.9%
Compound 4: middle estimate off by 1.1 percentage points, on the high side; the range from low to high includes it.
By their numbers in this assay, from the lowest: compounds 1 and 4 (each within the scatter of the next); then compound 3; then compound 2.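

The change from 4-chloro-6-methoxypyrimidin-2-yl to 4,6-dimethoxypyrimidin-2-yl comes to a number 4.6 percentage points higher from compound 1 to compound 4 (within the scatter) in this assay. Within the data shown here, this is the first single-place comparison in the set, and it shows that chloro and methoxy at this position cannot be told apart in this read-out. Nothing available explains this result.

From the compounds shown here alone, whether another group here, such as an amine or a longer chain like butoxy, would move growth inhibition beyond the scatter remains open. So does whether the same swap would give a similar result on a different core.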